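Dropping a Nitro Group on Two Related Cores

The source may hold more compounds than are shown below. What is called first, only, known or untested is meant among the compounds shown, and "the series" means these compounds.

Compound 1 `O=[N+]([O-])c1ccc(COc2ccc(Nc3ncnc4cc5c(cc34)OCCOCCOCCOCCO5)cc2)cc1` and compound 2 `O=[N+]([O-])c1ccc(COc2cccc(Nc3ncnc4cc5c(cc34)OCCOCCO5)c2)cc1` both carry a (4-nitrobenzyl)oxy group on cores whose difference is not broken down here. In a functional assay on HepG2 cells (Homo sapiens) for antiproliferative activity, read by MTT assay, with a stated time of 72 h (a higher number here means a weaker inhibitor, a lower number a stronger inhibitor), compound 1 gives only a limit, > 100000 nM. Compound 2 gives a number in this assay, 65300 nM. Compound 3 `c1ccc(COc2cccc(Nc3ncnc4cc5c(cc34)OCCOCCO5)c2)cc1` comes from compound 2 by one change, (hydrogen in place of nitro on an aromatic carbon). In this assay compound 3 gives a limit, > 100000 nM. The measured step is an at least 1.5-fold higher number from compound 2 to compound 3 (0.18 log units; that floor lies within the scatter). Two of the three values stop at the same place: the limit of > 100000 nM in this assay, at which 2 of the 3 values shown sit. Compound 4 `c1ccc(COc2ccc(Nc3ncnc4cc5c(cc34)OCCOCCOCCOCCO5)cc2)cc1` is the same change applied to compound 1, (hydrogen in place of nitro on an aromatic carbon). Compound 1 sits at a limit, > 100000 nM. Since the earlier step was upward or flat, the expected step is a step that the limit leaves unreadable from compound 1 to compound 4. Compound 4 is therefore expected near 150000 nM, between 70000 nM and 400000 nM.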

Compound 4, half-maximal inhibitory concentration: 11900 nM
Estimate against measurement, compound 4: 13-fold (1.10 log units) above; measured number below the stated range.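

Replacing the nitro group with hydrogen gives an at least 8.4-fold lower number from compound 1 to compound 4 (0.92 log units; beyond the scatter) in this assay. Set beside the earlier step, the same change does not carry over evenly from one core to the other: the same change on two cores in this assay, an at least 1.5-fold higher number (0.18 log units; that floor lies within the scatter) from compound 2 to compound 3 and an at least 8.4-fold lower number (0.92 log units; beyond the scatter) from compound 1 to compound 4, at least 12-fold (1.10 log units) apart, beyond the scatter of two such steps. This does not give the true size of either step, since each has a limit at one end, and it does not show which part of the cores lies behind the gap: the limit of > 100000 nM in this assay, at which 2 of the 4 values shown sit.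

The compounds shown leave open how other groups in place of nitro, such as an amine or a carboxylic acid on the same aromatic carbon, would behave on each core. They also leave open whether a third core would follow either step.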